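Halo swap on the aniline ring of a thiosemicarbazone series

The source may report more compounds than this note shows. Statements on the series, on what has been measured and on what is new or still open speak of the compounds shown alone.

Three compounds share one core and differ in the halogen on the aniline ring. Compound 1 `C/C(=N\NC(=S)Nc1ccc(I)cc1)c1ccccn1` gives 6.61 nM in a functional assay on MCF7 cells (Homo sapiens) for cytotoxicity, read by MTT assay, with a stated time of 48 h; a higher number here means a weaker inhibitor, a lower number a stronger inhibitor. Compound 3 `C/C(=N\NC(=S)Nc1ccc(F)cc1)c1ccccn1` gives 1.2 nM in this assay, and the step of a 5.5-fold lower number from compound 1 to compound 3 (0.74 log units; beyond the scatter) is the change (fluoro in place of iodo on an aromatic carbon). Compound 2 `C/C(=N/NC(=S)Nc1cccc(I)c1)c1ccccn1` gives 45 nM in this assay, the highest number of the three; the difference between the cores of compound 1 and compound 2 is not broken down here. Compound 4 `C/C(=N/NC(=S)Nc1cccc(F)c1)c1ccccn1` has not been measured. It differs from compound 2 by fluoro in place of iodo on an aromatic carbon, the same kind of change as from compound 1 to compound 3, though there the place is para to a large group and here meta to a large group. The step expected in this assay is a 5.0-fold lower number from compound 2 to compound 4 (0.70 log units; beyond the scatter), resting on a 5.5-fold lower number from compound 1 to compound 3 (0.74 log units; beyond the scatter), which is of the same kind. Compound 4 is therefore estimated at 9 nM, between 3 nM and 30 nM.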

Compound 4, half-maximal inhibitory concentration: 9 nM
Compound 4: middle estimate and measured number agree at the digits printed, and the stated range covers the measured number.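

In this assay, fluoro in place of iodo on an aromatic carbon gives the step (a 5.0-fold lower number from compound 2 to compound 4 (0.70 log units; beyond the scatter)). The change carries over between these two cores with much the same size: the same change on two cores in this assay, a 5.5-fold lower number (0.74 log units; beyond the scatter) from compound 1 to compound 3 and a 5.0-fold lower number (0.70 log units; beyond the scatter) from compound 2 to compound 4, 1.1-fold (0.04 log units) apart, within the scatter of two such steps. For the compounds shown here, this rests on only two matched pairs and a single halogen swap, so it shows transfer between the core of compound 1 and the core of compound 2 but says nothing about other cores, other groups or other assays, and it offers no explanation for the step.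

On these data alone, whether chloro, bromo, an amine, a carboxylic acid or a methoxy group on the aniline ring would follow the same course remains open. The compounds shown also leave open how much of the gap between the two cores belongs to each of their differences.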